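Benzofuran ketone ethers: amide tail variation on compound 1

The compounds below may be only part of what the source reports. "The series", "measured", "known", "first", "only" and "open" are said of these compounds alone.

Measured compounds:
compound 1 `CCCCc1oc2ccccc2c1C(=O)c1ccc(OCC(=O)N2CCCC2)cc1` — > 50000 nM
compound 2 `CCCCc1oc2ccccc2c1C(=O)c1ccc(OCC(=O)N[C@H](C)c2ccccc2)cc1` — 39000 nM
compound 3 `CCCCNC(=O)CCCOc1ccc(C(=O)c2c(CCCC)oc3ccccc23)cc1` — 38100 nM

In a functional assay on MDA-MB-231 cells (Homo sapiens) for antiproliferative activity, read by MTT assay, with a stated time of 24 h (on this read-out lower numbers stand for stronger inhibition and higher numbers for weaker inhibition), compound 1 gives > 50000 nM, which is a limit of the assay and not a number, so for compound 1 only a bound is known (the limit of > 50000 nM in this assay, at which 1 of the 3 values shown sits). In this assay compound 2 gives 39000 nM. In this assay compound 3 gives 38100 nM. The steps from compound 1 are an at least 1.2-fold lower number from compound 1 to compound 2 (0.10 log units; that floor lies within the scatter) and an at least 1.3-fold lower number from compound 1 to compound 3 (0.11 log units; that floor lies within the scatter), each a floor within the scatter; between the two measured numbers the step is a 1.0-fold lower number from compound 2 to compound 3 (0.01 log units; within the scatter).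

Compound 4 `CCCCc1oc2ccccc2c1C(=O)c1ccc(OCCCC(=O)N2CCOCC2)cc1` differs from compound 1 in this way: 2-((morpholin-4-yl)carbonyl)ethyl in place of (pyrrolidin-1-yl)carbonyl on a saturated chain carbon bound to an oxygen on an aromatic ring. Going by the values given here, the nearest measured step is the one to compound 3, where a longer chain carrying an amide also replaced the (pyrrolidin-1-yl)carbonyl, and it moved the number only at its floor, within the scatter. Among the compounds with values here, nothing among the measured compounds suggests a larger effect for the morpholine amide, so no step beyond the scatter is expected in this assay, with a real chance that compound 4 again returns only a limit.

The expected value for compound 4 is 45000 nM, within 20000 nM to 100000 nM. This estimate means a step of an at least 1.1-fold lower number from compound 1 to compound 4 (0.04 log units; that floor lies within the scatter).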

Compound 4, half-maximal inhibitory concentration: 31600 nM
Beside the measured number, compound 4's estimate is 1.4-fold (0.15 log units) above it, within the range that was stated.
By their numbers in this assay, from the lowest: compounds 4, 3 and 2 (each within the scatter of the next). At a limit, above all of these: compound 1.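

Compound 1 remains a limit of the assay and not a number, so its step to compound 4 is known only as a floor: the limit of > 50000 nM in this assay, at which 1 of the 4 values shown sits.

In this assay the change to 2-((morpholin-4-yl)carbonyl)ethyl from (pyrrolidin-1-yl)carbonyl gives a small step (an at least 1.5-fold lower number from compound 1 to compound 4 (0.19 log units; that floor lies within the scatter)), and morpholin-4-yl in place of butylamino on a carbonyl carbon gives another (a 1.2-fold lower number from compound 3 to compound 4 (0.08 log units; within the scatter)), so on the longer chain an amide without the amide hydrogen reads the same, within the scatter, as one that has it. The step that changes the chain and the amide tail together (a 1.2-fold lower number from compound 2 to compound 4 (0.09 log units; within the scatter)) also stays within the scatter, so compounds 2, 3 and 4 have no order among them, whether the amide nitrogen carries a morpholine ring, a butyl chain or a 1-phenylethyl group.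

As far as these compounds go, the effect of chain length alone stays open, and the morpholin-4-yl amide on the shorter chain of compound 1 or the pyrrolidin-1-yl amide on the longer chain of compound 4 would separate it from the change of ring. Also open, from the compounds shown here alone, is whether any group at this position moves the number beyond the scatter, for example a carboxylic acid or a piperazin-1-yl amide.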